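Thiosemicarbazones on a shared core: from benzyl to fluorophenyl

The source may report more compounds than this note shows. Statements on the series, on what has been measured and on what is new or still open speak of the compounds shown alone.

The compounds here share a thiosemicarbazone framework attached to a quinoline-type core, and they were tested in a functional assay on HT-29 cells (Homo sapiens) for antiproliferative activity, read by sulforhodamine B assay, with a stated time of 72 h; a lower number here means a stronger inhibitor, a higher number a weaker inhibitor. Compound 1, `S=C(NCc1ccccc1)N/N=C/c1ccc2ccccc2n1`, gives 75700 nM in this assay, the highest of the two plain numbers shown. The nearest neighbour is compound 3, `CC(C)c1cccc(C(C)C)c1NC(=S)N/N=C/c1ccc2ccccc2n1`, which gives 20700 nM in this assay, a gap beyond the usual scatter. Compound 2, `NC(=S)N/N=C/c1cnc2ccccc2n1`, is reported only as a limit of this assay, > 100000 nM, as described in the limit of > 100000 nM in this assay, at which 1 of the 3 values shown sits.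

Compound 4, `Fc1ccc(NC(=S)N/N=C/c2ccc3ccccc3n2)cc1`, has not yet been measured. It differs from compound 1 in one place: 4-fluorophenyl in place of benzyl on an amide-type nitrogen. No measured step of exactly this kind exists among these compounds, so the expectation rests on the single observation that compound 3, which carries a substituted phenyl ring directly on the same nitrogen, gives a lower number than compound 1. A small step toward a lower number, of modest size and possibly within the scatter, is therefore expected, a 1.5-fold lower number from compound 1 to compound 4 (0.18 log units; within the scatter). For compound 4 the estimate in this assay is 50000 nM, with a likely range from 15000 nM to 120000 nM.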

Compound 4, half-maximal inhibitory concentration: 28500 nM
Estimate against measurement, compound 4: 1.8-fold (0.24 log units) above, and the stated range covers the measured number.
By their numbers in this assay, from the lowest: compounds 3 and 4 (each within the scatter of the next); then compound 1. At a limit, above all of these: compound 2.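

In this assay the amide-type nitrogen now has its first measured step, as 4-fluorophenyl in place of benzyl gives a 2.7-fold lower number from compound 1 to compound 4 (0.42 log units; beyond the scatter) on the shared core. The two groups have the same count of heavy atoms and each holds one six-membered aromatic ring, so the number at this position can shift beyond the scatter while those counts stay unchanged. Nothing measured here accounts for the step.

The compounds shown leave open whether the fluorine or the loss of the extra carbon of benzyl matters, and a plain phenyl on this nitrogen would separate the two. Also open, going by these compounds, is how an amine or a carboxylic acid on that ring, or a longer chain in its place, would read in this assay.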